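From an Amide to a Urea on a Shared Core

The compounds below may be only part of what the source reports. "The series", "measured", "known", "first", "only" and "open" are said of these compounds alone.

Measured so far:
- compound 1, `O=C(NC1CCN(c2ncnc3[nH]ncc23)CC1)c1ccc(Br)cc1`, 16400 nM
- compound 2, `O=C(NC1CCN(c2ncnc3[nH]ncc23)CC1)c1ccccc1Cl`, 5240 nM

Both compounds were tested in an assay on isolated protein for inhibition of serine/threonine-protein kinase PAK 1 (Homo sapiens), read by ADP-Glo, with a stated time of 40 min; on this read-out lower numbers stand for stronger inhibition and higher numbers for weaker inhibition. Compound 2 gives the lowest number of the two, and its nearest neighbour is compound 1, with a 3.1-fold lower number from compound 1 to compound 2 (0.50 log units; beyond the scatter); that step exchanged one halogen-bearing phenyl for another on the carbonyl carbon.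

The next compound, compound 3, `Cc1cccc(C)c1NC(=O)NC1CCN(c2ncnc3[nH]ncc23)CC1`, changes the same position more deeply: (2,6-dimethylphenyl)amino in place of 2-chlorophenyl on a carbonyl carbon. The amide of compound 2 becomes a urea, since the entering group carries an amino link to the carbonyl carbon.

For the measured compounds named here, no measured step covers an exchange of this kind. Going by the values given here, the one step available, from compound 1 to compound 2, was of modest size and concerned only the pattern on the phenyl ring, so it says little about adding an amino link. With no direct guide, the expectation for compound 3 rests near the value of compound 2, with a wide range to either side: in this assay compound 3 is estimated at 4000 nM, between 1000 nM and 16000 nM, which would mean an expected step of a 1.3-fold lower number from compound 2 to compound 3 (0.12 log units; within the scatter).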

Compound 3, half-maximal inhibitory concentration: 2160 nM
Compound 3: middle estimate off by 1.9-fold (0.27 log units), on the high side; measured number inside the range.
By their numbers in this assay, from the lowest: compound 3; then compound 2; then compound 1.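

In this assay, the position on the carbonyl carbon accepts a urea as well as an amide: putting (2,6-dimethylphenyl)amino in place of 2-chlorophenyl gives a 2.4-fold lower number from compound 2 to compound 3 (0.38 log units; beyond the scatter). Set against the bromine-bearing amide, the same group gives a 7.6-fold lower number from compound 1 to compound 3 (0.88 log units; beyond the scatter), so compound 3 now has the lowest number of the three, and the earlier phenyl-for-phenyl step could not have shown that a group with an amino link on this carbonyl fits this series. Nothing available here accounts for why the number fell.

The step also changes two things at once, because the amino link arrives together with a different pattern on the phenyl ring, and the compounds shown cannot separate the share of each. On these data alone, a urea carrying (2-chlorophenyl)amino would isolate the link itself, while a cyclohexylamino group would ask whether the aromatic ring is needed on the urea at all, and both questions stay open.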